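This account rests on a few compounds, and the source may have more. Where it says the series, first, only, none or still open, it means among the compounds named here.

Working notes on the series. In an assay on isolated protein for agonist activity at Alpha-1A adrenergic receptor (Oryctolagus cuniculus) (on this read-out lower numbers stand for an effect already at smaller amounts and higher numbers for an effect only at larger amounts of compound), compound 2 `CCS(=O)(=O)Nc1cccc2c1CCCC2c1c[nH]cn1` gives 631 nM, the highest of the three numbers in hand. Compound 3 `CCS(=O)(=O)Nc1cccc2c1CCC[C@H]2c1c[nH]cn1` gives 170 nM, and compound 1 `CS(=O)(=O)Nc1c(O)ccc2c1CCCC2c1c[nH]cn1` gives 17 nM. Among the compounds with values here, the one step that changes a single place is a 3.7-fold lower number from compound 2 to compound 3 (0.57 log units; beyond the scatter); it rests on the fact that one of compounds 2 and 3 is drawn with a defined configuration and the other without, at the place where they differ and so concerns only the drawn configuration at the saturated ring carbon, not the sulfonyl substituent. Compound 1 differs from compound 2 in more than one place at once, so its value is noted but not read as a step.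

Compound 4 `CC(C)S(=O)(=O)Nc1cccc2c1CCCC2c1c[nH]cn1` carries methyl in place of hydrogen on a saturated chain carbon bound to a saturated chain carbon and a sulfonyl sulfur. Within the data shown here, none of the measured steps bears on this change: the step from compound 2 to compound 3 is a matter of configuration, and the pair of compound 2 and compound 1 is not a single-place pair. Among the measured compounds shown here, with no step of the ethyl-to-isopropyl kind available, the expectation for this assay is no step beyond the scatter, and compound 4 is expected at 700 nM, within 220 nM to 2200 nM. The expected step is accordingly a 1.1-fold higher number from compound 2 to compound 4 (0.05 log units; within the scatter).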

Compound 4, half-maximal effective concentration: 6760 nM
Compound 4: the middle estimate sits 9.7-fold (0.98 log units) below what was measured, and the stated range ends below it.
By their numbers in this assay, from the lowest: compound 1; then compound 3; then compound 2; then compound 4.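

Within the data shown here, the methyl added on the saturated chain carbon bound to a saturated chain carbon and a sulfonyl sulfur gives the only single-place step at the sulfonyl substituent, and in this assay it is large, with an 11-fold higher number from compound 2 to compound 4 (1.03 log units; beyond the scatter) as its size. Ethyl to isopropyl is therefore not a neutral exchange at this position, which a 3.7-fold lower number from compound 2 to compound 3 (0.57 log units; beyond the scatter) could not show, as that step leaves the sulfonyl substituent untouched. Nothing recorded for the series bears on the reason for this step.

Open, from the compounds shown here alone, is whether a propyl, tert-butyl or cyclopropyl group on the sulfonyl sulfur would follow isopropyl or ethyl. Also open, going by these compounds, is whether the step holds with the configuration drawn in compound 3, since compound 2 and compound 4 carry none at the saturated ring carbon.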